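From (tert-butyl)amino to diethylamino in a cell assay

The source may hold more compounds than are shown below. What is called first, only, known or untested is meant among the compounds shown, and "the series" means these compounds.

Of the compounds shown here, three built on a shared core have been read in an ADME assay on CHO cells (Cricetulus griseus) for inhibition, read by MTT assay; a higher number here means a weaker inhibitor, a lower number a stronger inhibitor. Compound 1 `CCN(CC)Cc1cccc(Nc2nc3ccccc3[nH]2)c1O` gives > 50000 nM, which is a limit of the assay and not a number. Compound 2 `CCN(CC)Cc1cc(C)cc(Nc2nc3ccccc3n2Cc2ccc(C#N)cc2)c1O` gives 14200 nM. Compound 3 `Cc1cc(CNC(C)(C)C)c(O)c(Nc2nc3ccccc3[nH]2)c1` gives 33300 nM, the higher of the two actual numbers, and its gap to compound 2 lies beyond the usual scatter.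

Compound 4 `CCN(CC)Cc1cc(C)cc(Nc2nc3ccccc3[nH]2)c1O` has not yet been measured. It differs from compound 3 by a single change: diethylamino in place of (tert-butyl)amino on a saturated chain carbon bound to an aromatic carbon. Diethylamino stands in place of (tert-butyl)amino on a saturated chain carbon bound to an aromatic carbon, so the two compounds have the same atoms, joined differently. Within the data shown here, no two measured compounds differ in one place only, which leaves no direct measure of such a change. Compound 3 at 33300 nM is therefore the reference, and no step beyond the scatter is expected in this assay, in either direction. The estimate is a 1.0-fold lower number from compound 3 to compound 4 (0.02 log units; within the scatter), an expected step that stays within the scatter. Compound 4 is expected at 32000 nM, with an estimated range from 16000 nM to 50000 nM.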

Compound 4, half-maximal inhibitory concentration: > 50000 nM
Compound 4 ended at the assay's limit; the forecaster's own chance of this, stated with the estimate: 25%; middle value at least 1.5-fold (0.19 log units) away from the limit.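

In this assay, among these compounds, diethylamino in place of (tert-butyl)amino on a saturated chain carbon bound to an aromatic carbon now has a direct reading, an at least 1.5-fold higher number from compound 3 to compound 4 (0.17 log units; that floor lies within the scatter), which shows only that this change brought no lower number. Among the compounds shown here, the result also gives the first direct reading of a change on the aromatic nitrogen: hydrogen in place of 4-cyanobenzyl gives an at least 3.5-fold higher number from compound 2 to compound 4 (0.54 log units; beyond the scatter), so within this pair the lower number goes with the 4-cyanobenzyl group. The step that places methyl for hydrogen on an aromatic carbon cannot be read, and the other two steps give only floors, not full sizes, all set by one limit of the assay: the limit of > 50000 nM in this assay, at which 2 of the 4 values shown sit.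

Still open, going by these compounds, is how far past that limit compound 4 truly lies, and whether a dimethylamino or morpholine group on the same saturated chain carbon would read differently from (tert-butyl)amino. Also open, on these data alone, is whether a plain benzyl or a 4-methoxybenzyl group on the aromatic nitrogen would keep the lower number seen with the 4-cyanobenzyl group of compound 2.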